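The compounds below may be only part of what the source reports. "The series", "measured", "known", "first", "only" and "open" are said of these compounds alone.

Measured so far in a functional assay on HEK293 cells for antagonist activity at Voltage-dependent L-type calcium channel subunit alpha-1C (Oryctolagus cuniculus), read by FLIPR; a lower number here means a stronger inhibitor, a higher number a weaker inhibitor:
compound 1 `CCOC(=O)C1=C(C)NC(/C=C/c2ccc([N+](=O)[O-])cc2)=C(C(=O)OCC)C1c1cccc([N+](=O)[O-])c1` — 1940 nM
compound 2 `C=CCOC(=O)C1=C(C)NC(C)=C(C(=O)OCC)C1c1cccc([N+](=O)[O-])c1` — 25 nM
compound 3 `COC(=O)C1=C(C)NC(C)=C(C(=O)OCc2ccccc2)C1c1cccc([N+](=O)[O-])c1` — 25 nM

Compound 3 stands level with compound 2 at the digits shown; the two share the lowest number of the three and lie within the scatter of each other, so no order between them can be read. Compound 1 sits far above both, a gap well beyond the scatter; nothing more than the two values themselves can be said of that pair.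

Next in line is compound 4 `COC(=O)C1=C(C)NC(C)=C(C(=O)OCCc2ccc(Cl)cc2)C1c1cccc([N+](=O)[O-])c1`. Relative to compound 3 the change is confined to one ester: 4-chlorobenzyl in place of phenyl on a saturated chain carbon bound to an oxygen next to a carbonyl group. The core, the other ester and the nitrophenyl substituent stay as in compound 3.

Within the data shown here, no step between measured compounds covers this kind of change. Among the measured compounds shown here, the only guidance is that compound 2 gives 25 nM and compound 3 gives 25 nM with different ester groups, so variation at the ester has so far left the number unchanged. A step in this assay of small size, in either direction or none beyond the scatter, is expected; a 1.2-fold higher number from compound 3 to compound 4 (0.08 log units; within the scatter) is the estimated step. Compound 4 is therefore expected at 30 nM, with a range from 10 nM to 90 nM.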

Compound 4, half-maximal inhibitory concentration: 8 nM
Compound 4: middle estimate off by 3.8-fold (0.57 log units), on the high side; measured number below the stated range.
By their numbers in this assay, from the lowest: compound 4; then compounds 2 and 3 (each within the scatter of the next); then compound 1.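

In this assay, the ester on this side of the shared core can move the number beyond the scatter: 4-chlorobenzyl in place of phenyl on a saturated chain carbon bound to an oxygen next to a carbonyl group gives a 3.1-fold lower number from compound 3 to compound 4 (0.49 log units; beyond the scatter). Among these compounds, this is the first step between compounds that differ in one place, so the earlier compounds could not show that this ester affects the read-out, or that the change moves it toward a stronger inhibitor. Read one bond further out, as benzyl to 2-(4-chlorophenyl)ethyl, the step joins a longer chain and a chlorine on the ring, and no measurement available here bears on why the number falls.

Which of these two differences carries the step stays open, since a phenylethyl ester with no chlorine or a 4-chlorobenzyl ester on the shorter chain would be needed to separate them. Also open, as far as these compounds go, is how the number responds to a different kind of group on this chain, such as an amine or a carboxylic acid.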